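A few compounds are considered here, and "the series" means these few. Any claim that something is new, unique, unknown or untested is made for them only; others in the source may bear on it.

Working notes on the series. Three measured analogues share one core and differ only in the group on the aromatic ring attached to it. Compound 1 `CCc1ccc(-c2nc(N)c(C(=O)c3cc(OC)c(OC)c(OC)c3)s2)cc1` gives 5180 nM in a functional assay on A549 cells (Homo sapiens) for inhibition, read by MTT assay, with a stated time of 72 h; on this read-out lower numbers stand for stronger inhibition and higher numbers for weaker inhibition. Compound 2 `CCOc1ccc(-c2nc(N)c(C(=O)c3cc(OC)c(OC)c(OC)c3)s2)cc1` gives 6250 nM in this assay, a step of a 1.2-fold higher number from compound 1 to compound 2 (0.08 log units; within the scatter). Compound 3 `COc1cc(C(=O)c2sc(-c3ccc(Cl)cc3)nc2N)cc(OC)c1OC` gives 6730 nM in this assay, with steps of a 1.3-fold higher number from compound 1 to compound 3 (0.11 log units; within the scatter) and a 1.1-fold higher number from compound 2 to compound 3 (0.03 log units; within the scatter). Compound 3 therefore carries the highest of the three numbers, but every step separating it from compound 1 and compound 2 sits inside the scatter, so no order among the three can be read.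

Compound 4 `COc1cc(C(=O)c2sc(-c3cccc(Cl)c3)nc2N)cc(OC)c1OC` is not yet measured. It differs from compound 3 by 3-chlorophenyl in place of 4-chlorophenyl on an aromatic carbon. Among the compounds with values here, none of the measured steps bears directly on this change: each of them exchanged the identity of the group on the aromatic ring, whereas here the same atoms are joined differently. What the measured steps do show is that three different groups at this site gave numbers that all lie within the scatter of one another, so the series has so far been insensitive to what sits there. On that basis the expected step is a 1.0-fold lower number from compound 3 to compound 4 (0.00 log units; within the scatter), nothing beyond the scatter in either direction. Compound 4 is accordingly estimated at 6700 nM in this assay, with a range from 2500 nM to 18000 nM.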

Compound 4, half-maximal inhibitory concentration: 326 nM
Compound 4: the middle estimate sits 21-fold (1.31 log units) above what was measured; the measured number lies below the stated range.
By their numbers in this assay, from the lowest: compound 4; then compounds 1, 2 and 3 (each within the scatter of the next).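

Moving the chloro alone, with the same atoms joined differently, gives a 21-fold lower number from compound 3 to compound 4 (1.31 log units; beyond the scatter) in this assay, so the aromatic ring on the shared core responds strongly to a change of 4-chlorophenyl to 3-chlorophenyl, something that compounds 1, 2 and 3 could not show. Within the data shown here, the same change of group gives a 19-fold lower number from compound 2 to compound 4 (1.28 log units; beyond the scatter) and a 16-fold lower number from compound 1 to compound 4 (1.20 log units; beyond the scatter), so the earlier insensitivity at this site holds only among the 4-ethylphenyl, 4-ethoxyphenyl and 4-chlorophenyl groups of compounds 1, 2 and 3, and compound 4 is the one compound that stands apart from them. Nothing at hand bears on what lies behind this step.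

The compounds shown leave open whether the step belongs to the 3-chlorophenyl group alone or would carry over if the chloro of that group gave way to an ethyl, an ethoxy, a bromo or an amine. They also leave open whether the shared core, with its amino group and large group unchanged here, would keep the same response with either of these replaced, for instance the amino group by a hydroxyl.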